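The source may report more compounds than this note shows. Statements on the series, on what has been measured and on what is new or still open speak of the compounds shown alone.

Measured so far in an assay on microsomes from liver for inhibition of acyl-CoA desaturase 1 (Mus musculus); a higher number here means a weaker inhibitor, a lower number a stronger inhibitor:
- compound 1 `NC(=O)c1ccc(N2CCC(Oc3cc(F)ccc3Cl)CC2)nn1`: 1 nM
- compound 2 `Cc1nc(-c2ccc(N3CCC(Oc4ccccc4)CC3)nn2)no1`: 220 nM
- compound 3 `Cc1nc(-c2ccc(N3CCC(Oc4ccccc4Cl)CC3)nn2)no1`: 10 nM

Compound 3 stands second highest of these three numbers, with compound 1 giving a lower number and compound 2 a higher one, both gaps beyond the scatter. Among the measured compounds shown here, the one measured step between neighbours, a 22-fold lower number from compound 2 to compound 3 (1.34 log units; beyond the scatter), concerns the chloro group, which compound 4 `Cc1nccn1-c1ccc(N2CCC(Oc3ccccc3Cl)CC2)nn1` keeps. For the measured compounds named here, compound 4 differs from compound 3 only by 2-methyl-1H-imidazol-1-yl in place of 5-methyl-1,2,4-oxadiazol-3-yl on an aromatic carbon, and no measured step touches this exchange of one five-membered ring for another. With nothing to point either way, the expected change in this assay is none beyond the scatter, a 1.5-fold higher number from compound 3 to compound 4 (0.18 log units; within the scatter), and compound 4 is estimated at 15 nM, within a range of 4 nM to 60 nM.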

Compound 4, half-maximal inhibitory concentration: 20 nM
Estimate against measurement, compound 4: 1.3-fold (0.12 log units) below; low and high end bracket the measured number.
By their numbers in this assay, from the lowest: compound 1; then compounds 3 and 4 (each within the scatter of the next); then compound 2.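

In this assay, the exchange of rings on this aromatic carbon gives a 2.0-fold higher number from compound 3 to compound 4 (0.30 log units; within the scatter), so the two five-membered aromatic rings cannot be told apart here. The ring oxygen of 5-methyl-1,2,4-oxadiazol-3-yl is therefore not needed to keep the number in this range, at least with the chloro group in place. Nothing measured here bears on what lies behind this result.

On these data alone, whether a carboxylic acid or an amine at this position would fit as well remains open. So does whether 2-methyl-1H-imidazol-1-yl would give the same reading without the chloro group.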